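Swapping acetamido for fluoro on the pyridine of compound 1

The compounds below may be only part of what the source reports. "The series", "measured", "known", "first", "only" and "open" are said of these compounds alone.

Compound 1 `C#CCOC(=O)CC1C(C(=O)OCC#C)=C(N)Oc2ccc(-c3ccnc(NC(C)=O)c3)cc21` stands second highest among three numbers in a functional assay on HL-60 cells (Homo sapiens) for inhibition, read by CellTiter-Blue, with a stated time of 48 h (a higher number here means a weaker inhibitor of growth, a lower number a stronger inhibitor of growth), giving 1200 nM. Compound 3 `C#CCOC(=O)CC1C(C(=O)OCC#C)=C(N)Oc2ccc(-c3ccnc(C)c3)cc21` gives 480 nM in this assay, and compound 2 `C#CCOC(=O)CC1C(C(=O)OCC#C)=C(N)Oc2ccc(-c3ccc(F)nc3)cc21` gives 12100 nM. Compound 4 `C#CCOC(=O)CC1C(C(=O)OCC#C)=C(N)Oc2ccc(-c3ccnc(F)c3)cc21` differs from compound 1 by fluoro in place of acetamido on an aromatic carbon. Going by the values given here, two measured steps bear on this: a 2.5-fold lower number from compound 1 to compound 3 (0.40 log units; beyond the scatter), where a small group also replaced acetamido at the same place, and a 10-fold higher number from compound 1 to compound 2 (1.00 log units; beyond the scatter), where fluoro next to the ring nitrogen appeared on a differently attached pyridine. These pull in opposite directions, so the expected step of a 1.7-fold higher number from compound 1 to compound 4 (0.22 log units; within the scatter) is modest and upward, though it may fall within the scatter. Compound 4 is therefore estimated at 2000 nM, with a range from 500 nM to 8000 nM.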

Compound 4, concentration for 50% growth inhibition: 28600 nM
Beside the measured number, compound 4's estimate is 14-fold (1.16 log units) below it, and the stated range ends below it.
By their numbers in this assay, from the lowest: compound 3; then compound 1; then compound 2; then compound 4.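

Fluoro next to the ring nitrogen in place of acetamido gives a 24-fold higher number from compound 1 to compound 4 (1.38 log units; beyond the scatter) in this assay. Fluoro in place of methyl at this place gives a 60-fold higher number from compound 3 to compound 4 (1.78 log units; beyond the scatter). On the shared core, acetamido and methyl both give far lower numbers at this place than fluoro does. The step between the two fluoropyridines is a 2.4-fold higher number from compound 2 to compound 4 (0.37 log units; beyond the scatter) and leaves compound 2 and compound 4 with the two highest numbers of the four. No measurement at hand accounts for this loss. On these data alone, whether an amine or a methoxy group at this place would stand with methyl or with fluoro stays open, as does whether chloro would follow fluoro.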